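The source may report more compounds than this note shows. Statements on the series, on what has been measured and on what is new or still open speak of the compounds shown alone.

Compound 1 `Cc1ccc(NC(=O)Nc2ccc(Oc3cc(NCc4ccccc4)ncn3)cc2)cc1C(F)(F)F` opens the series; in a functional assay on BaF3 cells (Mus musculus) for inhibition, read by CCK-8 assay, with a stated time of 72 h (on this read-out lower numbers stand for stronger inhibition of growth and higher numbers for weaker inhibition of growth), compound 1 gives 3010 nM. Compound 2 `Cc1ccc(NC(=O)Nc2ccc(Oc3cc(NCCN)ncn3)cc2)cc1C(F)(F)F` carries a 2-aminoethyl chain on the ring nitrogen instead of the benzyl group. In this assay compound 2 reaches only a limit of the assay, > 10000 nM, so no number is known for it. Compound 3 `Cc1ccc(NC(=O)Nc2ccc(Oc3cc(N)ncn3)cc2)cc1C(F)(F)F` carries hydrogen on that nitrogen. In this assay compound 3 likewise sits at a limit, > 10000 nM. The steps of an at least 3.3-fold higher number from compound 1 to compound 2 (0.52 log units; beyond the scatter) and an at least 3.3-fold higher number from compound 1 to compound 3 (0.52 log units; beyond the scatter) both run toward weaker inhibition, while a step that the two limits leave unreadable from compound 2 to compound 3 cannot be sized, as both values rest on (the limit of > 10000 nM in this assay, at which 2 of the 3 values shown sit). Compound 4 `Cc1ccc(NC(=O)Nc2ccc(Oc3cc(NCCO)ncn3)cc2)cc1C(F)(F)F` is the next member: hydroxy in place of amino on a saturated chain carbon, two bonds along the chain from a nitrogen on an aromatic ring. For the measured compounds named here, no measured step exchanges these two groups, and compound 2 itself offers only a limit, so the expectation must lean on the two steps that leave the benzyl group. Compound 4 is expected to show a step that the limit leaves unreadable from compound 2 to compound 4, that is, no clear change. The estimated value of compound 4 in this assay is 15000 nM, within 5000 nM to 50000 nM.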

Compound 4, concentration for 50% growth inhibition: > 10000 nM
Compound 4: only a limit was reported (the forecaster's own chance of this, stated with the estimate: 70%); the middle value lies beyond the limit too.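

In this assay compound 4 gives > 10000 nM which is a limit of the assay and not a number. The 2-hydroxyethyl chain on the ring nitrogen thus falls in with the 2-aminoethyl chain and with plain hydrogen, with an at least 3.3-fold higher number from compound 1 to compound 4 (0.52 log units; beyond the scatter) running the same way as the two earlier steps away from the benzyl group, and hydroxy in place of amino at the chain end brings back no measurable value. The steps among compound 2, compound 3 and compound 4 cannot be read, as all three values rest on one limit: the limit of > 10000 nM in this assay, at which 3 of the 4 values shown sit.

From the compounds shown here alone, whether a 2-phenylethyl or a cyclohexylmethyl group on that nitrogen would give stronger inhibition than the benzyl group of compound 1 stays open. Going by these compounds, how far compound 2, compound 3 and compound 4 lie beyond the limit also stays unknown, so no order among them can be given.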